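The source may hold more compounds than are shown below. What is called first, only, known or untested is meant among the compounds shown, and "the series" means these compounds.

Compound 2 `COc1ccc(CS(=O)(=O)/C=C/c2c(OC)cccc2OC)cc1` gives 700 nM in a functional assay on DLD-1 cells (Homo sapiens) for antiproliferative activity, read by trypan blue exclusion; on this read-out higher numbers stand for weaker inhibition and lower numbers for stronger inhibition. Compound 1 `COc1cc(OC)c(/C=C/S(=O)(=O)Cc2ccc([N+](=O)[O-])cc2)c(OC)c1`, which carries a nitro group on the benzyl ring and three methoxy groups on the styryl ring, gives 15000 nM in this assay. For compound 3 `COc1ccc(CS(=O)(=O)/C=C/c2ccc(OC)cc2OC)cc1` only a limit is known: its value of > 20000 nM in this assay is the limit of the assay and not a number, the point described as the limit of > 20000 nM in this assay, at which 1 of the 3 values shown sits. Compound 3 therefore stands at the weak end of what has been measured, with no number to place it against compound 1 or compound 2.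

Compound 4 `COc1ccc(CS(=O)(=O)/C=C/c2c(OC)cc(OC)cc2OC)cc1` is the not yet measured member of the set. It differs from compound 3 by methoxy in place of hydrogen on an aromatic carbon. Within the data shown here, no step between two measured compounds of the set matches this change. Because compound 2 gives 700 nM while sharing the two methoxy groups flanking the vinyl attachment that compound 4 also carries, the step from compound 3 to compound 4 is expected to run towards stronger inhibition, by an at least 8.0-fold lower number from compound 3 to compound 4 (0.90 log units; beyond the scatter). Compound 4 is expected to give about 2500 nM in this assay, within a range from 500 nM to 15000 nM.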

Compound 4, half-maximal inhibitory concentration: 40 nM
Estimate against measurement, compound 4: 63-fold (1.80 log units) above; the measured number lies below the stated range.
By their numbers in this assay, from the lowest: compound 4; then compound 2; then compound 1. At a limit, above all of these: compound 3.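

Methoxy in place of hydrogen on the aromatic carbon ortho to a large group gives an at least 500-fold lower number from compound 3 to compound 4 (2.69 log units; beyond the scatter), so in this assay this one place separates the weak end of the set from its strongest member, compound 4. For compound 3 that step rests on a limit and not a number: the limit of > 20000 nM in this assay, at which 1 of the 4 values shown sits. The change does not act alone, since methoxy in place of hydrogen at another place gives an 18-fold lower number from compound 2 to compound 4 (1.24 log units; beyond the scatter), and methoxy in place of nitro gives a 380-fold lower number from compound 1 to compound 4 (2.57 log units; beyond the scatter), although compound 1 carries the same three methoxy groups on the styryl ring as compound 4.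

The compounds shown leave open whether a longer chain, such as ethoxy, could stand in place of the entering methoxy. They also leave open how an amine or a carboxylic acid in place of the methoxy on the benzyl ring would read.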